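The source may report more compounds than this note shows. Statements on the series, on what has been measured and on what is new or still open speak of the compounds shown alone.

Of the compounds shown here, three of a shared core have been measured so far. Compound 1 `CC(O)(C(=O)Nc1ccc(S(=O)(=O)c2ccc(F)cc2)cc1)C(F)(F)F` bears a 4-fluorophenyl on its sulfonyl sulfur, and in a functional assay (Cavia porcellus) with sulfonylurea receptors; K-ATP channels (Homo sapiens) as the target (a lower number here means a stronger inhibitor, a higher number a weaker inhibitor), compound 1 gives 8600 nM. Compound 2 `COc1cc(C(=O)c2ccccc2)ccc1NC(=O)C(C)(O)C(F)(F)F` gives 6100 nM, and compound 3 `Cc1cc(C(=O)c2ccccc2)ccc1NC(=O)C(C)(O)C(F)(F)F` gives 5000 nM. For the measured compounds named here, the only step between measured compounds that differ in one place is a 1.2-fold lower number from compound 2 to compound 3 (0.09 log units; within the scatter), methyl in place of methoxy on an aromatic carbon. Compound 1 stands at the highest of the three numbers, but its gaps to compound 2 and to compound 3 both lie within the scatter, so the three cannot be set in any order.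

Compound 4 `CC(O)(C(=O)Nc1ccc(S(=O)(=O)c2cncs2)cc1)C(F)(F)F` differs from compound 1 in one place: 1,3-thiazol-5-yl in place of 4-fluorophenyl on a sulfonyl sulfur. Going by the values given here, no measured step touches the group on the sulfonyl sulfur; the single step available concerns a substituent on the aromatic core and itself stays within the scatter, so it gives no guidance on this change. With nothing pointing in either direction, the expected step is a 1.2-fold lower number from compound 1 to compound 4 (0.09 log units; within the scatter), within the scatter. Compound 4 is therefore estimated at 7000 nM, with a range from 2500 nM to 20000 nM.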

Compound 4, half-maximal inhibitory concentration: 7700 nM
Beside the measured number, compound 4's estimate is 1.1-fold (0.04 log units) below it; measured number inside the range.
By their numbers in this assay, from the lowest: compounds 3, 2, 4 and 1 (each within the scatter of the next).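

In this assay, for the compounds shown here, the exchange of 4-fluorophenyl for 1,3-thiazol-5-yl on a sulfonyl sulfur gives a 1.1-fold lower number from compound 1 to compound 4 (0.05 log units; within the scatter), the first measured step at this position. Across this pair, the six-membered aromatic ring of carbon only gives way to a five-membered aromatic ring with 2 hetero atoms, and the count of hydrogen-bond acceptors on the group goes from 0 to 2, yet the step stays within the scatter of this assay. No measurement shown here offers an explanation for this result.

Going by these compounds, the two aromatic groups compared on the sulfonyl sulfur therefore cannot be told apart by this read-out, but whether the same holds for a non-aromatic group there, such as a simple alkyl chain, an amine or a carboxylic acid, stays open. Also open, on these data alone, is whether a methyl or a methoxy on an aromatic carbon of the shared core would leave the number similarly unmoved in compounds that carry the sulfonyl group of compound 1 and compound 4.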